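The compounds below may be only part of what the source reports. "The series", "measured", "known", "first", "only" and "open" are said of these compounds alone.

Three compounds share one core and differ only in the aromatic group at the end of the chain. Compound 1 `O=C(CCCc1ccc(Cl)cc1)N1CCc2c(Cl)c(O)c(O)c(Cl)c2C1` gives 80% in a functional assay (Homo sapiens), tested at 1 uM (on this read-out higher numbers stand for a weaker effect at the one concentration tested and lower numbers for a stronger effect), compound 2 `O=C(CCCc1ccc(F)cn1)N1CCc2c(Cl)c(O)c(O)c(Cl)c2C1` gives 89%, and compound 3 `O=C(CCCc1ccc([N+](=O)[O-])cn1)N1CCc2c(Cl)c(O)c(O)c(Cl)c2C1` gives 74%, the lowest of the three numbers; its gap to compound 1 lies within the scatter, whereas the step of a number 15 percentage points lower from compound 2 to compound 3 (beyond the scatter) lies beyond it. Compound 4 `O=C(CCCc1ccc(C(F)(F)F)cn1)N1CCc2c(Cl)c(O)c(O)c(Cl)c2C1` has not yet been measured and carries trifluoromethyl in place of nitro on an aromatic carbon. For the measured compounds named here, the only measured step at this position is a number 15 percentage points lower from compound 2 to compound 3 (beyond the scatter), and no measured pair involves a trifluoromethyl, so the direction is open; a number near compound 3 or drifting back toward compound 1 seems plausible. Compound 4 is therefore expected to give 80%, between 65% and 95%, an expected step of a number 6 percentage points higher from compound 3 to compound 4 (within the scatter).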

Compound 4, a percentage reported as activity, at one concentration (the size of the read-out at that concentration, not a potency): 72%
Estimate against measurement, compound 4: 8 percentage points above; the range from low to high includes it.
By their numbers in this assay, from the lowest: compounds 4, 3, 1 and 2 (each within the scatter of the next, the first and the last beyond it).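

Swapping nitro for trifluoromethyl gives a number 2 percentage points lower from compound 3 to compound 4 (within the scatter) in this assay and so leaves the read-out unchanged within the scatter at this aromatic carbon. Set against fluoro, trifluoromethyl gives a number 17 percentage points lower from compound 2 to compound 4 (beyond the scatter) and so a second group, alongside nitro, now stands apart from fluoro at this position. Nothing measured here explains why these groups differ from fluoro. On these data alone, whether an amine or a carboxylic acid at this carbon would move the number further remains open. So does whether trifluoromethyl would behave the same way on a longer chain.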